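The source may report more compounds than this note shows. Statements on the series, on what has been measured and on what is new or still open speak of the compounds shown alone.

Measured in an ADME assay on BJ cells (Homo sapiens), read by MTT assay, with a stated time of 72 h; a lower number here means a stronger inhibitor, a higher number a weaker inhibitor:
- compound 1 `CSc1ncnc2c1c(-c1ccoc1)cn2[C@@H]1O[C@H](CO)[C@@H](O)[C@H]1O`: 98800 nM
- compound 2 `CNc1ncnc2c1c(-c1ccoc1)cn2[C@@H]1O[C@H](CO)[C@@H](O)[C@H]1O`: 96300 nM
- compound 3 `CNc1ncnc2c1c(-c1cccs1)cn2[C@@H]1O[C@H](CO)[C@@H](O)[C@H]1O`: > 100000 nM (a limit of the assay, not a number)

Compound 2 and compound 1 stand within the scatter of each other, and the only other result is the limit. Next in the series is compound 4 `CN(C)c1ncnc2c1c(-c1ccoc1)cn2[C@@H]1O[C@H](CO)[C@@H](O)[C@H]1O`, which differs from compound 2 as follows: methyl in place of hydrogen on a nitrogen on an aromatic ring. This is methyl in place of hydrogen on a nitrogen on an aromatic ring, or methylamino to dimethylamino.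

Within the data shown here, no measured step makes this exact change. The closest is a 1.0-fold lower number from compound 1 to compound 2 (0.01 log units; within the scatter), methylamino in place of methylsulfanyl on an aromatic carbon, which stays within the scatter. The change of thiophen-2-yl in place of furan-3-yl gives an at least 1.0-fold higher number from compound 2 to compound 3 (0.01 log units; that floor lies within the scatter), and that floor also lies within the scatter. No step beyond the scatter is therefore expected in this assay. The expected change is a 1.1-fold lower number from compound 2 to compound 4 (0.05 log units; within the scatter). A report only as a limit is also possible for compound 4, as with the limit of > 100000 nM in this assay, at which 1 of the 3 values shown sits. The estimated value for compound 4 is 85000 nM, with an expected range of 35000 nM to 100000 nM.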

Compound 4, half-maximal inhibitory concentration: 99200 nM
Estimate against measurement, compound 4: 1.2-fold (0.07 log units) below, within the range that was stated.
By their numbers in this assay, from the lowest: compounds 2, 1 and 4 (each within the scatter of the next). At a limit, above all of these: compound 3.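

In this assay, methyl in place of hydrogen on a nitrogen on an aromatic ring gives a 1.0-fold higher number from compound 2 to compound 4 (0.01 log units; within the scatter), and dimethylamino in place of methylsulfanyl on an aromatic carbon gives a 1.0-fold higher number from compound 1 to compound 4 (0.00 log units; within the scatter). With furan-3-yl kept, methylsulfanyl, methylamino and dimethylamino at this position now read alike across compounds 1, 2 and 4, so the hydrogen on that nitrogen can be replaced by methyl with no readable change in this assay. Compound 3 stays a limit of the assay, not a number: the limit of > 100000 nM in this assay, at which 1 of the 4 values shown sits.

Going by these compounds, whether a plain amino group or a longer chain such as ethylamino at this position would separate from these three remains open. The same holds for a carboxylic acid in place of furan-3-yl, with dimethylamino kept.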